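This account rests on a few compounds, and the source may have more. Where it says the series, first, only, none or still open, it means among the compounds named here.

Compound 2 `COc1ccc(-c2cccc3c2N(S(=O)(=O)c2ccc(OC)cc2)CC3)cc1` gives 211 nM in a functional assay on MKN-45 cells (Homo sapiens) for inhibition, with a stated time of 72 h (a lower number here means a stronger inhibitor, a higher number a weaker inhibitor), and so has the highest of the two numbers measured here, while compound 1 `COc1ccc(S(=O)(=O)N2CCc3cccc(-c4ccc(F)c(F)c4)c32)cc1` gives 55.5 nM. Among the measured compounds shown here, the single step between them, a 3.8-fold higher number from compound 1 to compound 2 (0.58 log units; beyond the scatter), comes from changing the group on this same aromatic carbon, so it bears directly on the next change. Compound 3 `COc1ccc(S(=O)(=O)N2CCc3cccc(-c4cccs4)c32)cc1` differs from compound 2 in that (thiophen-2-yl in place of 4-methoxyphenyl on an aromatic carbon). For the measured compounds named here, the one measured step shows that swapping the group at this place moved the number beyond the scatter, though only modestly, so a step of similar size, in either direction, is expected, with a shift back toward compound 1 somewhat more likely because compound 1 gives the lower 55.5 nM. The step of a 1.9-fold lower number from compound 2 to compound 3 (0.28 log units; within the scatter) is therefore the estimate. Compound 3 is expected to give about 110 nM, within a range from 35 nM to 400 nM.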

Compound 3, half-maximal inhibitory concentration: 165 nM
Estimate against measurement, compound 3: 1.5-fold (0.18 log units) below; measured number inside the range.
By their numbers in this assay, from the lowest: compound 1; then compounds 3 and 2 (each within the scatter of the next).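

In this assay, replacing the six-membered 4-methoxyphenyl with the five-membered thiophen-2-yl on this aromatic carbon gives a 1.3-fold lower number from compound 2 to compound 3 (0.11 log units; within the scatter), so at this position, these two quite different rings cannot be told apart. Among the compounds shown here, replacing 3,4-difluorophenyl with thiophen-2-yl gives a 3.0-fold higher number from compound 1 to compound 3 (0.47 log units; beyond the scatter), which means that compound 1 now stands apart from both compound 2 and compound 3, and 3,4-difluorophenyl is the only one of the three groups to give a number beyond the scatter of the others. Nothing measured here explains this difference.

The compounds shown leave open whether both fluorines are needed, as a plain phenyl or a 4-fluorophenyl would help to show. They also leave open how a pyridin-3-yl ring, or a non-aromatic amine such as morpholine, would behave on this carbon.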